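The source may hold more compounds than are shown below. What is called first, only, known or untested is meant among the compounds shown, and "the series" means these compounds.

Measured in a functional assay on MDA-MB-231 cells (Homo sapiens) for antiproliferative activity, read by MTT assay, with a stated time of 48 h; on this read-out lower numbers stand for stronger inhibition and higher numbers for weaker inhibition:
Compound 1 `COc1ccc(N(C)c2ccnc(Cl)n2)cc1F`: 1280 nM
Compound 2 `COc1ccc(N(C)c2ccnc(Cl)n2)cc1OCCCC[Se]C#N`: > 10000 nM
Compound 3 `COc1ccc(N(C)c2cc(C)nc(C)n2)cc1`: 3650 nM

The entry for compound 2 is a limit, not a number.

Compound 3, at 3650 nM, has a higher number than compound 1, at 1280 nM. Compound 4 `COc1ccc(N(C)c2cc(C)nc(C)n2)cc1[N+](=O)[O-]` carries nitro in place of hydrogen on an aromatic carbon, ortho to a methoxy group (nitro in place of hydrogen on an aromatic carbon).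

Within the data shown here, only one measured step bears on this change. A larger chain replacing fluorine on an aromatic carbon gave an at least 7.8-fold higher number from compound 1 to compound 2 (0.89 log units; beyond the scatter), beyond the scatter and upward. Nitro is a smaller group than that chain, so only a small upward move is expected in this assay.

The expected step is a 1.2-fold higher number from compound 3 to compound 4 (0.09 log units; within the scatter). For compound 4 the estimate is 4500 nM, with an expected range from 1500 nM to 10000 nM.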

Compound 4, half-maximal inhibitory concentration: 3440 nM
Compound 4: middle estimate off by 1.3-fold (0.12 log units), on the high side; low and high end bracket the measured number.
By their numbers in this assay, from the lowest: compound 1; then compounds 4 and 3 (each within the scatter of the next). At a limit, above all of these: compound 2.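

In this assay, nitro in place of hydrogen on an aromatic carbon, ortho to a methoxy group, gives a 1.1-fold lower number from compound 3 to compound 4 (0.03 log units; within the scatter). Among these compounds, this is the first step at this place that ends in two numbers, and it shows that, on the core of compound 3, nitro leaves the read-out within the scatter. The earlier step at this place rested on a limit, not a number: the limit of > 10000 nM in this assay, at which 1 of the 4 values shown sits.

From the compounds shown here alone, whether an amine or a carboxylic acid at this place would also stay within the scatter remains open. So does whether nitro would behave the same way on the core of compound 1.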